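Amino acid replacement on the glycinamide carbonyl

A few compounds are considered here, and "the series" means these few. Any claim that something is new, unique, unknown or untested is made for them only; others in the source may bear on it.

Compound 1 `O=C(O)[C@@H]1CCCN1C(=O)CN(c1nc(Cl)nc2[nH]cnc12)C1CC1` stands highest of the three numbers in a functional assay on the whole organism (Tail, strain ICR) with Mus musculus as the target, in the tail flick test, with a stated time of 60 min, at a dose of 25 umol/kg by the oral route (on this read-out lower numbers stand for a weaker effect and higher numbers for a stronger effect at the one dose given), compound 1 giving 34.9%, though within the scatter of both others. Compound 3 `O=C(OCc1ccccc1)[C@@H]1CCCN1C(=O)CN(c1nc(Cl)nc2[nH]cnc12)C1CC1` gives 34.4% and compound 2 `CSCC[C@H](NC(=O)CN(c1nc(Cl)nc2[nH]cnc12)C1CC1)C(=O)OCc1ccccc1` gives 30.8%. Among the compounds with values here, the only counted step, a number 0.5 percentage points lower from compound 1 to compound 3 (within the scatter), concerns the ester oxygen, not the group on the carbonyl carbon. Compound 4 `C[C@H](NC(=O)CN(c1nc(Cl)nc2[nH]cnc12)C1CC1)C(=O)O` differs from compound 1 by (1-carboxyethyl)amino in place of 2-carboxypyrrolidin-1-yl on a carbonyl carbon. Within the data shown here, no measured step covers this change directly; compound 2 and compound 3 share the benzyl ester and differ on the carbonyl carbon, and their two values lie within the scatter of each other. The step is therefore expected to stay within the scatter: a number 2.9 percentage points lower from compound 1 to compound 4 (within the scatter). Compound 4 is estimated at 32%, expected range 20% to 45%.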

Compound 4, a percentage reported as activity, at one dose (the size of the read-out at that dose, not a potency): 44.6%
For compound 4 the middle estimate is 12.6 percentage points below the measured one, and the stated range covers the measured number.
By their numbers in this assay, from the lowest: compounds 2, 3, 1 and 4 (each within the scatter of the next, the first and the last beyond it).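

With (1-carboxyethyl)amino in place of 2-carboxypyrrolidin-1-yl on a carbonyl carbon, this assay reads a number 9.7 percentage points higher from compound 1 to compound 4 (within the scatter). The five-membered ring is therefore not needed at this place for a read-out of this size, at this one dose, even with the group that enters carrying one more hydrogen-bond donor by count. Nothing available explains the size of this step. Open: whether a benzyl ester of the (1-carboxyethyl)amino group reads like its free carboxylic acid, and whether an amine or a longer chain is tolerated in place of the methyl of that group.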